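The source may hold more compounds than are shown below. What is called first, only, known or untested is meant among the compounds shown, and "the series" means these compounds.

Measured in a functional assay on M14 cells (Homo sapiens) for inhibition, with a stated time of 48 h; a higher number here means a weaker inhibitor of growth, a lower number a stronger inhibitor of growth:

Compound 1 `COc1ccccc1/C=C/C(=O)c1c(O)cc2occc2c1OC`: > 100000 nM (a limit of the assay)
Compound 2 `COc1c(C(=O)/C=C/c2ccc(Cl)cc2)c(O)c(Br)c2occc12`: 4820 nM
Compound 3 `C=CCc1c(O)c(C(=O)/C=C/c2ccccc2)c(OC)c2ccoc12`: 5360 nM

Only compound 2 and compound 3 have actual numbers in this assay, and those two values lie within the usual scatter of each other. Compound 1 reached only the limit of > 100000 nM, so it gives no number to set beside them. Compound 3 therefore stands level with compound 2 on the data at hand.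

The next compound, compound 4 `C=CCc1c(O)c(C(=O)/C=C/c2ccc(Cl)cc2)c(OC)c2ccoc12`, differs from compound 3 in a single place: chloro in place of hydrogen on an aromatic carbon. This puts chloro in place of hydrogen on an aromatic carbon, para to a large group, turning phenyl into 4-chlorophenyl.

Among the measured compounds shown here, no measured pair isolates this change. Compound 2 carries the same 4-chlorophenyl group and gives 4820 nM, but its structure also differs from compound 3 elsewhere, so it offers only loose guidance. A small move towards a lower number is expected, at about the edge of the scatter, and no large change is foreseen. The expected change is a 1.4-fold lower number from compound 3 to compound 4 (0.15 log units; within the scatter). For compound 4 the estimated value is 3800 nM, with an expected range from 1600 nM to 9000 nM.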

Compound 4, concentration for 50% growth inhibition: 5080 nM
Beside the measured number, compound 4's estimate is 1.3-fold (0.13 log units) below it, within the range that was stated.
By their numbers in this assay, from the lowest: compounds 2, 4 and 3 (each within the scatter of the next). At a limit, above all of these: compound 1.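

In this assay, the pair that isolates chloro in place of hydrogen, on an aromatic carbon para to a large group, gives a 1.1-fold lower number from compound 3 to compound 4 (0.02 log units; within the scatter), so phenyl and 4-chlorophenyl cannot be told apart at this position in this series. With the 4-chlorophenyl group held constant, allyl in place of bromo on an aromatic carbon gives a 1.1-fold higher number from compound 2 to compound 4 (0.02 log units; within the scatter), so this second change cannot be told apart from the scatter either. Nothing available bears on either of these two steps.

Going by these compounds, whether a different group at the place now held by chloro, such as an amine or a carboxylic acid, would give a step beyond the scatter remains open. Among the compounds shown here, compound 1 gives > 100000 nM, a limit of the assay, and no step in a single place links it to the other compounds, so which of its structural differences matters remains open too.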